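Two Diaryl Ethers, One Substituent Swap, Same Assay

The source may hold more compounds than are shown below. What is called first, only, known or untested is meant among the compounds shown, and "the series" means these compounds.

Compound 1, `CCOC(=O)c1ccc(Oc2ccc(C#N)cc2)cc1`: in a functional assay on HL-60 cells (Homo sapiens) for antiproliferative activity (a higher number here means a weaker inhibitor, a lower number a stronger inhibitor), compound 1 gives > 20000 nM, which is a limit of the assay rather than a number.
Compound 2, `CCOC(=O)c1ccc(Oc2ccc(N(C)C)cc2)cc1`: in this assay compound 2 gives > 20000 nM, again a limit and not a number.
Compound 3, `COc1cccc(OC)c1Oc1ccc(C#N)cc1`: in this assay compound 3 gives > 20000 nM, also a limit and not a number.

The three measured compounds share a diaryl ether motif but fall into two cores. Compound 1 and compound 3 differ in more than one place, and the difference between the two cores is not broken down here. Within the first core, compound 2 is made from compound 1 by the change (dimethylamino in place of cyano on an aromatic carbon). The size of that step is a step that the two limits leave unreadable from compound 1 to compound 2, because of the limit of > 20000 nM in this assay, at which 3 of the 3 values shown sit.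

Compound 4, `COc1cccc(OC)c1Oc1ccc(N(C)C)cc1`, is not yet measured. It is made from compound 3 by the change (dimethylamino in place of cyano on an aromatic carbon). The place of the change is the same in both pairs, so this is the same change, now applied to the second core.

The expectation for compound 4 rests only on what compound 3 shows, > 20000 nM, and on the fact that the same change left compound 2 at > 20000 nM. Going by the values given here, the step from compound 3 to compound 4 is therefore expected to be a step that the limit leaves unreadable from compound 3 to compound 4, which is only an estimate, since no measured step in these data has a readable size. Compound 4 is expected to give about 30000 nM in this assay, most likely reported as a limit, with the estimate spanning from 12000 nM to 100000 nM.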

Compound 4, half-maximal inhibitory concentration: 11400 nM
Beside the measured number, compound 4's estimate is 2.6-fold (0.42 log units) above it; measured number outside the range, below it.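

In this assay, putting dimethylamino in place of cyano on the core of compound 3 gives an at least 1.7-fold lower number from compound 3 to compound 4 (0.24 log units; that floor lies within the scatter); this figure is only a floor, since one end of the step is a limit, so the data do not establish a true difference beyond the usual scatter. Compound 2, which carries the same dimethylamino group on the other core, gives > 20000 nM, which is a limit and not a number. The change therefore brings one compound, compound 4, to a readable number, but it cannot be said to behave alike or differently in the two cores, and the step from compound 1 to compound 2 cannot be read, because so many values sit at the top of the range: the limit of > 20000 nM in this assay, at which 3 of the 4 values shown sit.

The compounds shown leave open how a diethylamino group, a primary amine or a carboxylic acid in that same place would fare on either core. They also leave open whether the modest number of compound 4 belongs to dimethylamino alone or needs the two methoxy groups of its core, since no comparison between the two cores can be read here.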